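This account rests on a few compounds, and the source may have more. Where it says the series, first, only, none or still open, it means among the compounds named here.

Working notes on the series, with a functional assay on Jurkat cells for inhibition of nuclear factor NF-kappa-B complex (Homo sapiens) (on this read-out higher numbers stand for weaker inhibition and lower numbers for stronger inhibition), as the read-out.

Compound 2 `CCOC(=O)c1cnc(-c2ccc(F)cc2)nc1NN1C(=O)C=C(C)C1=O` gives 700 nM in this assay. Compound 1 `CCOC(=O)c1cnc(-c2csc(C)n2)nc1NN1C(=O)C=C(C)C1=O` gives 8000 nM. Going by the values given here, of the two numbers known so far, compound 2 holds the lowest; its nearest neighbour is compound 1, and the step of an 11-fold lower number from compound 1 to compound 2 (1.06 log units; beyond the scatter) sets the two apart.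

Compound 3 `CCOC(=O)c1cnc(-c2ccc(Cl)cc2)nc1NN1C(=O)C=C(C)C1=O` has not been measured. It differs from compound 2 by chloro in place of fluoro on an aromatic carbon. Among the compounds with values here, no measured step exchanges one halogen for another on the aromatic carbon para to a large group; the one step known, an 11-fold lower number from compound 1 to compound 2 (1.06 log units; beyond the scatter), replaces the whole aryl group and so does not speak to a fluoro-to-chloro exchange. Nothing in the data therefore argues for a move beyond the scatter in either direction, and the expectation is that compound 3 stays close to compound 2, with a 1.2-fold lower number from compound 2 to compound 3 (0.07 log units; within the scatter) as the estimated step.

For compound 3 the estimate in this assay is 600 nM, with an expected range from 250 nM to 1500 nM.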

Compound 3, half-maximal inhibitory concentration: 300 nM
The estimate for compound 3 lay 2.0-fold (0.30 log units) above the measured number; the range from low to high includes it.
By their numbers in this assay, from the lowest: compound 3; then compound 2; then compound 1.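

In this assay, the aromatic carbon para to a large group responds to the exchange of a single atom: chloro in place of fluoro gives a 2.3-fold lower number from compound 2 to compound 3 (0.37 log units; beyond the scatter), a modest step but one beyond the scatter. The earlier pair could not show this, since it changed the whole aryl group and left the halogen untouched. With chloro in place, the replacement of 2-methyl-1,3-thiazol-4-yl by the substituted phenyl gives a 27-fold lower number from compound 1 to compound 3 (1.43 log units; beyond the scatter), so the halogen adds a small further change to a large one, and nothing at hand indicates what lies behind the difference between fluoro and chloro.

On these data alone, two halogens give no trend, so it remains open whether bromo on the same aromatic carbon would lower the number further, or whether a methoxy, an amine or a carboxylic acid there would keep it in the range of compound 3. As far as these compounds go, it also remains open whether chloro in place of fluoro would give a step of similar size with changes elsewhere on the shared core, such as a carboxylic acid in place of the ethyl ester.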